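Trimming the hydroxycarbamoyl chain of compound 1

A few compounds are considered here, and "the series" means these few. Any claim that something is new, unique, unknown or untested is made for them only; others in the source may bear on it.

Going by the values given here, in a functional assay on MDA-MB-231 cells (Homo sapiens) for inhibition, read by MTT assay, with a stated time of 72 h (a higher number here means a weaker inhibitor, a lower number a stronger inhibitor), compound 1 (`Nc1ncnc2c1c(-c1cnc3[nH]ccc3c1)nn2CCCCCCCCC(=O)NO`) gives 11000 nM and compound 2 (`Nc1nc2cc(-c3nn(CCCC(=O)NO)c4ncnc(N)c34)ccc2o1`) gives 19500 nM as the only numbers measured so far. The two lie within the usual scatter of each other, so compound 1 cannot be ranked against compound 2. Compound 3 (`Nc1ncnc2c1c(-c1cnc3[nH]ccc3c1)nn2CCCCCCC(=O)NO`) keeps the core of compound 1 and alters only the chain. The change is hydroxycarbamoyl in place of 2-(hydroxycarbamoyl)ethyl on a saturated chain carbon, six bonds along the chain from an aromatic nitrogen and reads as hydroxycarbamoyl in place of 2-(hydroxycarbamoyl)ethyl on a saturated chain carbon, six bonds along the chain from an aromatic nitrogen. Among the compounds with values here, no two measured compounds differ in one place, so this assay offers no direct guide to this change. The expectation rests only on how close compound 1 at 11000 nM lies to compound 2 at 19500 nM and points to no shift beyond the scatter, with a slight lean toward a lower number. The expected size is a 1.6-fold lower number from compound 1 to compound 3 (0.20 log units; within the scatter) and remains tentative. For compound 3 the estimated value is 7000 nM with an expected range from 2000 nM to 20000 nM in this assay once it is measured.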

Compound 3, half-maximal inhibitory concentration: 37700 nM
For compound 3 the middle estimate is 5.4-fold (0.73 log units) below the measured one; measured number outside the range, above it.
By their numbers in this assay, from the lowest: compounds 1, 2 and 3 (each within the scatter of the next, the first and the last beyond it).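

Trimming the chain is not neutral at this position: in this assay, hydroxycarbamoyl in place of 2-(hydroxycarbamoyl)ethyl on a saturated chain carbon, six bonds along the chain from an aromatic nitrogen, gives a 3.4-fold higher number from compound 1 to compound 3 (0.53 log units; beyond the scatter) and so a weaker inhibitor. Going by these compounds alone, this is the first direct reading of a single change, since the earlier compounds formed no pair that differed in one place, and it shows that chain length alone can move the number beyond the scatter while the core and the hydroxycarbamoyl end stay the same. Nothing given here accounts for the size or direction of this step.

Within the data shown here, a single step fixes only one direction of change, so it remains open whether a chain longer than that of compound 1 would lower the number further or raise it again, and whether the change in number is smooth or abrupt along the chain. As far as these compounds go, it is also open how the chain of compound 1 would fare with a carboxylic acid or a primary amide at its end in place of the hydroxycarbamoyl group.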